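The source may report more compounds than this note shows. Statements on the series, on what has been measured and on what is new or still open speak of the compounds shown alone.

For the measured compounds named here, compound 1 `C[C@@H](O[C@H]1CN2C(=O)C=C(c3ccccc3)CC2[C@@H]1c1ccc(F)cc1)c1cc(C(F)(F)F)cc(C(F)(F)F)c1` gives 89.5 nM in an assay on CHO cells for displacement of a labelled ligand from Substance-P receptor (Homo sapiens), in the presence of a further agent that is not named here (a lower number here means a stronger inhibitor, a higher number a weaker inhibitor), the higher of the two numbers measured so far. Compound 2 `C[C@@H](O[C@H]1CN2C(=O)C=C(c3ccncc3)CC2[C@@H]1c1ccc(F)cc1)c1cc(C(F)(F)F)cc(C(F)(F)F)c1` gives 8.1 nM in this assay. Compound 3 `Cc1cc(C2=CC(=O)N3C[C@H](O[C@H](C)c4cc(C(F)(F)F)cc(C(F)(F)F)c4)[C@@H](c4ccc(F)cc4)C3C2)ccn1` differs from compound 1 by 2-methylpyridin-4-yl in place of phenyl on a double-bonded ring carbon. Going by the values given here, the one measured step that bears on this change, an 11-fold lower number from compound 1 to compound 2 (1.04 log units; beyond the scatter), was large. A lower number beyond the scatter is therefore expected for compound 3, with the step estimated as a 7.5-fold lower number from compound 1 to compound 3 (0.87 log units; beyond the scatter). In this assay compound 3 is expected to give about 12 nM, within a range from 4 nM to 35 nM.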

Compound 3, half-maximal inhibitory concentration: 34 nM
Estimate against measurement, compound 3: 2.8-fold (0.45 log units) below; measured number inside the range.
By their numbers in this assay, from the lowest: compound 2; then compound 3; then compound 1.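

In this assay the 2-methylpyridin-4-yl group still improves on phenyl, with a 2.6-fold lower number from compound 1 to compound 3 (0.42 log units; beyond the scatter) as the net result. The methyl in place of hydrogen on the aromatic carbon gives back part of the gain from the pyridine, with a 4.2-fold higher number from compound 2 to compound 3 (0.62 log units; beyond the scatter) remaining beyond the scatter. This change is thus sensitive to a single methyl on the pyridine ring, not only to the exchange of phenyl for pyridin-4-yl. As far as these compounds go, it remains open whether a methoxy, an amine or a chlorine on that same aromatic carbon would be tolerated any better. Nothing given here accounts for the cost of the methyl.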